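This account rests on a few compounds, and the source may have more. Where it says the series, first, only, none or still open, it means among the compounds named here.

Measured in a functional assay on A549 cells (Homo sapiens) for antiproliferative activity, read by MTT assay, with a stated time of 96 h; a lower number here means a stronger inhibitor of growth, a higher number a weaker inhibitor of growth:
- compound 1 `Cc1cc(-c2ccc(F)cc2)n(Cc2ccc(C(=O)NO)cc2)n1` gives 33000 nM
- compound 2 `O=C(CCCNC(=O)c1cc(-c2ccc(F)cc2)[nH]n1)NO` gives > 100000 nM, a limit of the assay

Compound 2 has no numerical value, and its only entry is the limit > 100000 nM. Compound 3 `O=C(CCCCCNC(=O)c1cc(-c2ccc(F)cc2)[nH]n1)NO` carries 2-(hydroxycarbamoyl)ethyl in place of hydroxycarbamoyl on a saturated chain carbon, three bonds along the chain from an amide-type nitrogen. Compound 1 at 33000 nM is the only numerical anchor in this assay, so a value in that region is expected. Another limit remains possible for compound 3. A moderate gain in growth inhibition is expected, with an estimated at least 2.5-fold lower number from compound 2 to compound 3 (0.39 log units; beyond the scatter). For compound 3 the estimated value is 40000 nM, with an expected range of 12000 nM to 100000 nM.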

Compound 3, concentration for 50% growth inhibition: 7090 nM
For compound 3 the middle estimate is 5.6-fold (0.75 log units) above the measured one; measured number outside the range, below it.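

In this assay, lengthening hydroxycarbamoyl to 2-(hydroxycarbamoyl)ethyl on the saturated chain carbon gives an at least 14-fold lower number from compound 2 to compound 3 (1.14 log units; beyond the scatter), so chain length alone moves this series from the assay limit to a measurable number. The entry for compound 2, > 100000 nM, is a limit and not a number, so the step has only a lower bound: the limit of > 100000 nM in this assay, at which 1 of the 3 values shown sits.

Going by these compounds, two chain lengths cannot define an optimum, and a longer chain such as 4-(hydroxycarbamoyl)butyl remains open. On these data alone, whether a carboxylic acid can stand in place of the hydroxycarbamoyl end also remains open.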